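Compound 3 and a new group on a carbonyl carbon

This account rests on a few compounds, and the source may have more. Where it says the series, first, only, none or still open, it means among the compounds named here.

Values so far in a functional assay on SGC-7901 cells (Homo sapiens) for cytotoxicity, read by sulforhodamine B assay, with a stated time of 72 h (on this read-out lower numbers stand for stronger inhibition and higher numbers for weaker inhibition), are:

- compound 1 `C=C1C(=O)O[C@@H]2CC(C)=C([C@@H](C)CCCOC(C)=O)[C@@H](OC(=O)CN(CC)CC)[C@H]12` gives 11600 nM
- compound 2 `C=C1C(=O)O[C@@H]2CC(C)=C([C@@H](C)CCCOC(C)=O)[C@@H](OC(=O)CN3CCCCC3)[C@H]12` gives 11500 nM
- compound 3 `C=C1C(=O)O[C@@H]2CC(C)=C([C@@H](C)CCCOC(C)=O)[C@@H](OC(=O)COc3cccc4cccnc34)[C@H]12` gives 14300 nM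

Compound 3 stands level with the other two, its value lying within the usual scatter of both. Compound 4 `C=C1C(=O)O[C@@H]2CC(C)=C([C@@H](C)CCCOC(C)=O)[C@@H](OC(=O)c3ccc(F)cc3)[C@H]12` carries 4-fluorophenyl in place of ((quinolin-8-yl)oxy)methyl on a carbonyl carbon. For the measured compounds named here, no measured step makes this exact change. The nearest ones swap groups on a saturated chain carbon bound to a carbonyl carbon: a 1.0-fold lower number from compound 1 to compound 2 (0.00 log units; within the scatter) and a 1.2-fold higher number from compound 1 to compound 3 (0.09 log units; within the scatter) and a 1.2-fold higher number from compound 2 to compound 3 (0.09 log units; within the scatter) all stay within the scatter. In this assay no step beyond the scatter is therefore expected, and no direction can be favoured. The estimated change is a 1.2-fold lower number from compound 3 to compound 4 (0.08 log units; within the scatter). The estimate for compound 4 is 12000 nM within an expected range of 4500 nM to 28000 nM.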

Compound 4, half-maximal inhibitory concentration: 13600 nM
The estimate for compound 4 lay 1.1-fold (0.05 log units) below the measured number; the measured number falls inside the stated range.
By their numbers in this assay, from the lowest: compounds 2, 1, 4 and 3 (each within the scatter of the next).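

In this assay, the group on this carbonyl carbon can lose its nitrogen altogether while the number stays within the scatter: a 1.1-fold lower number from compound 3 to compound 4 (0.02 log units; within the scatter) and a 1.2-fold higher number from compound 2 to compound 4 (0.07 log units; within the scatter) and a 1.2-fold higher number from compound 1 to compound 4 (0.07 log units; within the scatter) all show this. The earlier compounds shown here only exchanged groups on the saturated chain carbon, whereas 4-fluorophenyl replaces that chain carbon too and still stands level with all three. No evidence is available to explain this level result.

From the compounds shown here alone, whether unsubstituted phenyl, or a longer chain ending in a carboxylic acid, on this carbonyl carbon would move the number beyond the scatter stays open.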